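Aryl exchange on the shared core: note on compound 3

The source may hold more compounds than are shown below. What is called first, only, known or untested is meant among the compounds shown, and "the series" means these compounds.

Compound 1 `COc1cc(C(=O)c2sc(-c3ccc(C)cc3)cc2N)cc(OC)c1OC` gives 16 nM in a functional assay on MOLT-4 cells (Homo sapiens) for antiproliferative activity; a higher number here means a weaker inhibitor, a lower number a stronger inhibitor.
Compound 2 `COc1cc(C(=O)c2sc(-c3ccc(Cl)c(Cl)c3)cc2N)cc(OC)c1OC` gives 270 nM in this assay.

Compound 2 stands highest of the two numbers; its nearest neighbour is compound 1, with a 17-fold higher number from compound 1 to compound 2 (1.23 log units; beyond the scatter) separating them. Compound 3 `CCOc1ccc(-c2cc(N)c(C(=O)c3cc(OC)c(OC)c(OC)c3)s2)cc1` differs from compound 2 by 4-ethoxyphenyl in place of 3,4-dichlorophenyl on an aromatic carbon. Within the data shown here, the only step that bears on the aryl group is a 17-fold higher number from compound 1 to compound 2 (1.23 log units; beyond the scatter), and it was large. Because a 17-fold higher number from compound 1 to compound 2 (1.23 log units; beyond the scatter) shows that the aryl group moves the number strongly, and because 4-ethoxyphenyl is closer in kind to 4-methylphenyl than to 3,4-dichlorophenyl, the expected step is a 9.0-fold lower number from compound 2 to compound 3 (0.95 log units; beyond the scatter). Compound 3 is estimated at 30 nM, within 10 nM to 100 nM.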

Compound 3, half-maximal inhibitory concentration: 240 nM
Estimate against measurement, compound 3: 8.0-fold (0.90 log units) below; the measured number lies above the stated range.
By their numbers in this assay, from the lowest: compound 1; then compounds 3 and 2 (each within the scatter of the next).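

Replacing 3,4-dichlorophenyl with 4-ethoxyphenyl gives a 1.1-fold lower number from compound 2 to compound 3 (0.05 log units; within the scatter), so this assay does not separate these two aryl groups at this position. The other comparison is the sharper one: a 15-fold higher number from compound 1 to compound 3 (1.18 log units; beyond the scatter), so ethoxy in place of methyl on the aryl group is enough for a large step, with no chlorine involved. No supporting data explain this step. Still open, going by these compounds, is where 4-methoxyphenyl and 4-ethylphenyl would fall, and with them whether the step follows the ether oxygen or the longer chain.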